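Shifting the Chlorine: 4-Chlorobenzyl to 3-Chlorobenzyl

The source may hold more compounds than are shown below. What is called first, only, known or untested is meant among the compounds shown, and "the series" means these compounds.

Compound 1 `C#CCOc1ccc2c(=O)c(-c3cc(OC)c(OC)cc3OC)coc2c1`: 6450 nM
Compound 2 `COc1cc(OC)c(-c2coc3cc(OCc4ccccc4F)ccc3c2=O)cc1OC`: 2890 nM
Compound 3 `COc1cc(OC)c(-c2coc3cc(OCc4ccc(Cl)cc4)ccc3c2=O)cc1OC`: 470 nM

These compounds share one core and differ only in the group on a saturated chain carbon bound to an oxygen on an aromatic ring. In a functional assay on U-251 cells (Homo sapiens) for antiproliferative activity, read by MTT assay, with a stated time of 24 h (on this read-out higher numbers stand for weaker inhibition and lower numbers for stronger inhibition), compound 3 gives 470 nM, the lowest number of the three, which makes it the strongest inhibitor so far.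

The next compound, compound 4 `COc1cc(OC)c(-c2coc3cc(OCc4cccc(Cl)c4)ccc3c2=O)cc1OC`, has 3-chlorophenyl in place of 4-chlorophenyl (3-chlorophenyl in place of 4-chlorophenyl on a saturated chain carbon bound to an oxygen on an aromatic ring). The atoms stay the same, and only the way they are joined changes.

Going by the values given here, no measured step isolates this change. The closest is a 6.1-fold lower number from compound 2 to compound 3 (0.79 log units; beyond the scatter), but there the halogen and its place on the ring change together. Two larger or smaller steps away from the ethynyl compound, a 14-fold lower number from compound 1 to compound 3 (1.14 log units; beyond the scatter) and a 2.2-fold lower number from compound 1 to compound 2 (0.35 log units; beyond the scatter), show that this group can move the number substantially. Among the compounds with values here, compound 2, the only other compound with a halogen on this ring, sits higher at 2890 nM, so a modest rise in the number seems more likely than a fall.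

The expected change is a 2.0-fold higher number from compound 3 to compound 4 (0.31 log units; beyond the scatter). Compound 4 is estimated at 950 nM, with an expected range of 300 nM to 3000 nM.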

Compound 4, half-maximal inhibitory concentration: > 10000 nM
Compound 4 ended at the assay's limit (the forecaster's own chance of this, stated with the estimate: 2%); middle value at least 10-fold (1.02 log units) from the limit.
By their numbers in this assay, from the lowest: compound 3; then compound 2; then compound 1. At a limit, above all of these: compound 4.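

Moving the chlorine matters far more at this position than the earlier compounds could show: going from 4-chlorobenzyl to 3-chlorobenzyl, with the same atoms joined differently, gives an at least 21-fold higher number from compound 3 to compound 4 (1.32 log units; beyond the scatter), so in these two compounds the place of the chlorine, and not just its presence, decides the number. The 3-chlorobenzyl group also does worse than the 2-fluorophenyl group of the earlier compound, with an at least 3.4-fold higher number from compound 2 to compound 4 (0.53 log units; beyond the scatter), while the comparison with the ethynyl compound stays unsettled, with an at least 1.5-fold higher number from compound 1 to compound 4 (0.19 log units; that floor lies within the scatter), whose floor does not clear the scatter. In this assay, going by these compounds alone, compound 4 gives > 10000 nM, which is a limit of the assay and not a number, and the only such value here: the limit of > 10000 nM in this assay, at which 1 of the 4 values shown sits.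

The compounds shown do not separate the halogen from its place on the ring, since neither a 2-chlorobenzyl nor a 4-fluorobenzyl group appears among them. On these data alone, how a methoxy group or a nitrile on this ring would read also stays open, as does a phenethyl group in place of the benzyl.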